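The source may hold more compounds than are shown below. What is called first, only, known or untested is meant among the compounds shown, and "the series" means these compounds.

Compound 3 `COc1cc2ncnc(NCc3cccc(NC(=O)Nc4cccc(C)c4)c3)c2cc1OC` is one of three close analogues examined in a functional assay on A549 cells (Homo sapiens) for antiproliferative activity, read by MTT assay; a higher number here means a weaker inhibitor, a lower number a stronger inhibitor. In that assay compound 3 gives 27100 nM, and compound 1 `Cc1ccccc1NC(=O)Nc1cccc(CNc2ncnc3ccccc23)c1` gives 40200 nM; these two numbers lie within the scatter of each other. For compound 2 `O=C(Nc1cccc(Cl)c1)Nc1cccc(CNc2ncnc3ccccc23)c1` this assay reports only a limit, > 50000 nM. Compound 4 `COc1cc2ncnc(NCc3cccc(NC(=O)Nc4cccc(C(F)(F)F)c4)c3)c2cc1OC` differs from compound 3 in one place: trifluoromethyl in place of methyl on an aromatic carbon, the 3-methylphenyl becoming 3-(trifluoromethyl)phenyl. For the measured compounds named here, the only measured step touching that aryl substituent is an at least 1.2-fold higher number from compound 1 to compound 2 (0.09 log units; that floor lies within the scatter), and it is bounded by the limit of > 50000 nM in this assay, at which 1 of the 3 values shown sits, so it offers no firm size. One therefore expects for compound 4 a step of a 1.3-fold higher number from compound 3 to compound 4 (0.11 log units; within the scatter), no larger than the scatter or a modest weakening. Compound 4 is estimated at 35000 nM, between 12000 nM and 100000 nM.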

Compound 4, half-maximal inhibitory concentration: 35300 nM
For compound 4 the middle estimate is 1.0-fold (0.00 log units) below the measured one; measured number inside the range.
By their numbers in this assay, from the lowest: compounds 3, 4 and 1 (each within the scatter of the next). At a limit, above all of these: compound 2.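

In this assay, the change at this position gives a step with a firm size, a 1.3-fold higher number from compound 3 to compound 4 (0.11 log units; within the scatter), so methyl and trifluoromethyl on this aromatic carbon are not told apart here. The earlier step on this aryl group gave no firm size because it ended at a limit: the limit of > 50000 nM in this assay, at which 1 of the 4 values shown sits.

As far as these compounds go, whether a group of another kind at this place, such as an amine or a carboxylic acid, would move the number beyond the scatter stays open. From the compounds shown here alone, it also stays open whether trifluoromethyl would behave the same way on the core of compound 1.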